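The source may report more compounds than this note shows. Statements on the series, on what has been measured and on what is new or still open speak of the compounds shown alone.

Measured in an ADME assay on HepG2 2.2.15 cells (Homo sapiens) for cytotoxicity, read by MTT assay; a higher number here means that more compound is tolerated, a lower number that less compound is tolerated:
Compound 1 `C=C1CC[C@@H]2[C@](C)(COC(=O)/C=C/c3cc(OC)c(OC)c(OC)c3)[C@H](O)CC[C@@]2(C)[C@@H]1/C=C/C1=CCOC1=O`: > 1700000 nM (a limit)
Compound 2 `C=C1CC[C@@H]2[C@](C)(COC(=O)c3ccco3)[C@H](O)CC[C@@]2(C)[C@@H]1/C=C/C1=CCOC1=O`: 92000 nM
Compound 3 `C=C1CC[C@@H]2[C@](C)(COC(=O)c3ccco3)[C@H](O)CC[C@@]2(C)[C@@H]1C/C=C1\C=COC1=O`: > 2150000 nM (a limit)

Compound 3 gives > 2150000 nM, which is a limit of the assay and not a number. Compound 4 `C=C1CC[C@@H]2[C@](C)(COC(=O)c3ccccc3C(=O)O)[C@H](O)CC[C@@]2(C)[C@@H]1C/C=C1\C=COC1=O` keeps the shared core and the group that compound 3 carries on the saturated ring carbon. It has 2-carboxyphenyl in place of furan-2-yl on a carbonyl carbon.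

For the measured compounds named here, no measured step covers this change. The nearest one, an at least 23-fold higher number from compound 2 to compound 3 (1.36 log units; beyond the scatter), is large, but it concerns the group on the saturated ring carbon, which stays the same in compound 4. The group on the carbonyl carbon differs only between compound 1 and compound 2, and these two share a different group on the saturated ring carbon. Compound 2 gives a number, 92000 nM. Compound 1 gives > 1700000 nM, which is again a limit. Going by the values given here, the group on the carbonyl carbon may therefore matter, though this has been seen only with that other group in place.

Compound 4 is expected to stay high in this assay, quite possibly at a limit again, so any step should be modest and downward. The expected change is an at least 2.1-fold lower number from compound 3 to compound 4 (0.33 log units; beyond the scatter). For compound 4 the estimate is 1000000 nM, with an expected range from 200000 nM to 2500000 nM.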

Compound 4, half-maximal cytotoxic concentration: 450000 nM
Beside the measured number, compound 4's estimate is 2.2-fold (0.35 log units) above it, within the range that was stated.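

In this assay, the group on the carbonyl carbon now shows an effect with the group of compound 3 on the saturated ring carbon in place, which compound 1 and compound 2 could not show, as they share a different group there. Placing 2-carboxyphenyl in place of furan-2-yl gives an at least 4.7-fold lower number from compound 3 to compound 4 (0.67 log units; beyond the scatter), and compound 4 gives a number rather than a limit. The full size of this step cannot be read because compound 3 stands at a limit and not at a number: the limit of > 2150000 nM in this assay, at which 1 of the 4 values shown sits.

The compounds shown leave open whether the step belongs to the carboxylic acid or to the six-membered aromatic ring that carries it, a question that a plain phenyl or a methyl ester on the same carbonyl carbon would address. They also leave open whether 2-carboxyphenyl would lower the number to the same extent with the group that compound 1 and compound 2 carry on the saturated ring carbon.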